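Amide aryl variation on the shared core: compound 4

The compounds below may be only part of what the source reports. "The series", "measured", "known", "first", "only" and "open" are said of these compounds alone.

Three amides sharing one core have been read in a functional assay on HCC1937 cells (Homo sapiens) for antiproliferative activity, read by CCK-8 assay, with a stated time of 72 h; on this read-out higher numbers stand for weaker inhibition and lower numbers for stronger inhibition. Compound 1 `COc1ccc(C(=O)Nc2cccc(-c3oc4cc(-c5ccc(F)cc5)ccc4c(=O)c3O)c2)cc1` gives 5490 nM. Compound 2 `O=C(Nc1cccc(-c2oc3cc(-c4ccc(F)cc4)ccc3c(=O)c2O)c1)c1ccc(F)cc1F` gives 6980 nM. Compound 3 `COc1cccc(C(=O)Nc2cccc(-c3oc4cc(-c5ccc(F)cc5)ccc4c(=O)c3O)c2)c1` gives 18900 nM, the highest of the three numbers. The step of a 1.3-fold higher number from compound 1 to compound 2 (0.10 log units; within the scatter) stays within the scatter, whereas a 3.4-fold higher number from compound 1 to compound 3 (0.54 log units; beyond the scatter) and a 2.7-fold higher number from compound 2 to compound 3 (0.43 log units; beyond the scatter) are modest steps beyond it, both ending at compound 3.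

Compound 4 `COc1cc(OC)cc(C(=O)Nc2cccc(-c3oc4cc(-c5ccc(F)cc5)ccc4c(=O)c3O)c2)c1` is not yet measured. It differs from compound 3 by methoxy in place of hydrogen on an aromatic carbon, on a carbon meta to a methoxy group, so that the 3-methoxyphenyl becomes a 3,5-dimethoxyphenyl. Going by the values given here, none of the measured steps adds a group to the amide aryl ring; each only exchanges one substituted ring for another, so no step bears directly on this change, and those exchanges shifted the number only modestly. For compound 4 the expected step is a 1.1-fold higher number from compound 3 to compound 4 (0.02 log units; within the scatter) in this assay, with no direction expected beyond the scatter. Compound 4 is therefore estimated at 20000 nM, within the range 8000 nM to 50000 nM.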

Compound 4, half-maximal inhibitory concentration: 6250 nM
Estimate against measurement, compound 4: 3.2-fold (0.51 log units) above, outside the stated range (below it).
By their numbers in this assay, from the lowest: compounds 1, 4 and 2 (each within the scatter of the next); then compound 3.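

In this assay, methoxy in place of hydrogen on an aromatic carbon, meta to a methoxy group, gives a 3.0-fold lower number from compound 3 to compound 4 (0.48 log units; beyond the scatter), a modest step beyond the scatter and the first case here of a group added to the amide aryl ring rather than one ring exchanged for another. The 3,5-dimethoxyphenyl amide does not separate from the other two amides, since a 1.1-fold lower number from compound 2 to compound 4 (0.05 log units; within the scatter) and a 1.1-fold higher number from compound 1 to compound 4 (0.06 log units; within the scatter) both lie within the scatter, which leaves the 3-methoxyphenyl amide, compound 3, alone with the highest number of the four. No measurement at hand accounts for this step.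

Going by these compounds, whether an amine, a carboxylic acid or an ethoxy at this place would match the methoxy remains open. Also open, on these data alone, is whether any change on this ring can take the number clearly below the values shared by compound 1, compound 2 and compound 4.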